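Series notes: chain length variation and a dichlorophenyl analogue

The source may report more compounds than this note shows. Statements on the series, on what has been measured and on what is new or still open speak of the compounds shown alone.

Measured so far in an assay on mitochondria (strain Sprague-Dawley) for inhibition of Amine oxidase [flavin-containing] B (Rattus norvegicus), read by fluorescence and Amplex Red, with stated times of 30 min and 45 min; on this read-out lower numbers stand for stronger inhibition and higher numbers for weaker inhibition:
- compound 1, `O=C(CCCc1ccccc1)Nc1nc2ccccc2c(=O)s1`: 186 nM
- compound 2, `O=C(C/C=C/c1ccccc1)Nc1nc2ccccc2c(=O)s1`: 361 nM
- compound 3, `O=C(CCc1ccccc1)Nc1nc2ccccc2c(=O)s1`: 42.7 nM

Compound 2 gives the highest of the three numbers in this assay. Its nearest neighbour is compound 1, whose value lies within the usual scatter of that of compound 2, so no order between these two can be read. Compound 3 stands furthest away, with a clearly lower number, a gap that lies beyond the scatter.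

Going by the values given here, the only single-point step among the measured compounds is a 4.4-fold lower number from compound 1 to compound 3 (0.64 log units; beyond the scatter), which concerns the chain and not the aromatic ring.

Compound 4, `O=C(C/C=C/c1ccc(Cl)c(Cl)c1)Nc1nc2ccccc2c(=O)s1`, differs from compound 2 by 3,4-dichlorophenyl in place of phenyl on a double-bonded chain carbon bound to a double-bonded chain carbon. Among the compounds with values here, no measured pair in this set varies the substitution on the phenyl ring, so the one step on hand does not bear on this change. Without such a precedent, no step beyond the scatter is expected in either direction in this assay.

Compound 4 is therefore expected to give about 350 nM in this assay, with a range from 90 nM to 1400 nM, which corresponds to an expected step of a 1.0-fold lower number from compound 2 to compound 4 (0.01 log units; within the scatter).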

Compound 4, half-maximal inhibitory concentration: 4640 nM
Compound 4: middle estimate off by 13-fold (1.12 log units), on the low side, outside the stated range (above it).
By their numbers in this assay, from the lowest: compound 3; then compounds 1 and 2 (each within the scatter of the next); then compound 4.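

In this assay, the phenyl ring on a double-bonded chain carbon bound to a double-bonded chain carbon proves sensitive to substitution: 3,4-dichlorophenyl in place of phenyl gives a 13-fold higher number from compound 2 to compound 4 (1.11 log units; beyond the scatter). The earlier compounds shown here varied only the chain, as in a 4.4-fold lower number from compound 1 to compound 3 (0.64 log units; beyond the scatter), and so said nothing about the aromatic ring; this single change now shows that the ring can shift the number by a large step in the unfavourable direction, with the chain and the shared core held constant. Nothing on hand accounts for the size or direction of this step.

The compounds shown leave open whether a single chlorine would carry the same step, and whether a smaller or different group on the phenyl ring, such as fluorine or methoxy, would be tolerated. They also leave open whether 3,4-dichlorophenyl would have a comparable effect on the saturated chain of compound 3, which gives 42.7 nM, or whether the step applies only to the chain with the double bond.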